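The source may report more compounds than this note shows. Statements on the series, on what has been measured and on what is new or still open speak of the compounds shown alone.

Measured so far in an assay on isolated protein for inhibition of complement C1r subcomponent (Homo sapiens); on this read-out lower numbers stand for stronger inhibition and higher numbers for weaker inhibition:
- compound 1 `Cc1ccccc1Nc1nc2ccccc2c(=O)o1` gives 31000 nM
- compound 2 `Cc1cccc(C)c1Nc1nc2ccccc2c(=O)o1` gives only a limit of the assay, > 62500 nM
- compound 3 `O=c1oc(Nc2nncs2)nc2ccccc12` gives only a limit of the assay, > 62500 nM

Compound 3 therefore stands nowhere on a measured scale: its value is a limit, not a number, and it shares that limit with one other compound, as the limit of > 62500 nM in this assay, at which 2 of the 3 values shown sit, records. Among the measured compounds shown here, compound 1 is the only member of the set with a measured number in this assay.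

Compound 4 `O=c1oc(Nc2nccs2)nc2ccccc12` is the unmeasured partner of compound 3. The change is 1,3-thiazol-2-yl in place of 1,3,4-thiadiazol-2-yl on a nitrogen on an aromatic ring. For the measured compounds named here, the single measured step, an at least 2.0-fold higher number from compound 1 to compound 2 (0.30 log units; that floor lies within the scatter), concerns a methyl added on an aromatic carbon of a different side chain and does not touch the heteroaryl group exchanged here, so no measured step bears on the change directly. Going by the values given here, the only guidance is that two of three values in this assay sit at the limit. Compound 4 is expected to remain close to that limit, with a step of an at least 1.0-fold lower number from compound 3 to compound 4 (0.01 log units; that floor lies within the scatter) expected, which cannot be read as a gain beyond the scatter. Compound 4 is thus estimated at 60000 nM, within 20000 nM to 200000 nM, and the assay may again report only a limit for it.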

Compound 4, half-maximal inhibitory concentration: > 62500 nM
Compound 4 gave a limit, no number (the forecaster's own chance of this, stated with the estimate: 60%); middle value at least 1.0-fold (0.01 log units) from the limit.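

In this assay, among the compounds shown here, compound 3 and compound 4 both give only a limit of the assay, not a number, so no step between them can be read: the limit of > 62500 nM in this assay, at which 3 of the 4 values shown sit. The compounds shown leave open whether 1,3-thiazol-2-yl and 1,3,4-thiadiazol-2-yl differ at all on this read-out, and where compound 3 and compound 4 would stand on a measured scale.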